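A Free Amine Returns on a Longer Chain

The source may hold more compounds than are shown below. What is called first, only, known or untested is meant among the compounds shown, and "the series" means these compounds.

Measured compounds:
compound 1 `CN[C@@H](CC(C)C)CN(C(=O)[C@@H]1C[C@H]1c1ccccc1)c1ccc(-c2ccccc2)cc1` — 2 nM
compound 2 `CC[C@H](C)[C@@H](CN(C(=O)[C@@H]1C[C@H]1c1ccccc1)c1ccc(-c2ccccc2)cc1)NC(C)=O` — 5.8 nM
compound 3 `NC1(CN(C(=O)[C@@H]2C[C@H]2c2ccccc2)c2ccc(-c3ccccc3)cc2)CCCC1` — 0.57 nM

In a functional assay for agonist activity at G protein-coupled receptor 88 (Homo sapiens), read by HTRF and cAMP accumulation (on this read-out lower numbers stand for an effect already at smaller amounts and higher numbers for an effect only at larger amounts of compound), compound 2 stands highest of the three numbers. The two steps that reach it, a 2.9-fold higher number from compound 1 to compound 2 (0.46 log units; beyond the scatter) and a 10-fold lower number from compound 2 to compound 3 (1.01 log units; beyond the scatter), are both beyond the scatter, and in each the partner carrying an amine in place of the 1-acetamido-2-methylbutyl group has the lower number.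

Compound 4 `CCC(CC)C(N)CCN(C(=O)[C@@H]1C[C@H]1c1ccccc1)c1ccc(-c2ccccc2)cc1` has not been measured. It differs from compound 2 in one place: 2-amino-3-ethylpentyl in place of 1-acetamido-2-methylbutyl on a saturated chain carbon bound to an amide-type nitrogen. Both measured steps from compound 2 bear on this change, since again the acetamido group leaves and an amine enters, here on the 2-amino-3-ethylpentyl chain. Compound 4 is therefore expected to show a modest to large step down, a 3.9-fold lower number from compound 2 to compound 4 (0.59 log units; beyond the scatter). Compound 4 is estimated at 1.5 nM, with a range from 0.4 nM to 6 nM.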

Compound 4, half-maximal effective concentration: 2 nM
For compound 4 the middle estimate is 1.3-fold (0.12 log units) below the measured one, within the range that was stated.
By their numbers in this assay, from the lowest: compound 3; then compounds 1 and 4 (each within the scatter of the next); then compound 2.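

In this assay, a free amine again gives the lower number on the 2-amino-3-ethylpentyl chain, with a 2.9-fold lower number from compound 2 to compound 4 (0.46 log units; beyond the scatter) as the step away from the acetamido group. The amine on this chain matches the 3-methyl-1-(methylamino)butyl group, with no change at the digits printed from compound 1 to compound 4 (within the scatter) at this position. The ring-bearing 1-aminocyclopentyl group still keeps its edge, with a 3.5-fold higher number from compound 3 to compound 4 (0.55 log units; beyond the scatter) on leaving it for the open chain. No measurement shown explains these steps. Going by these compounds, whether a dimethylamino group or a carboxylic acid on the 2-amino-3-ethylpentyl chain would hold this level remains open.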